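Swapping the sulfonyl aryl group on a shared core

A few compounds are considered here, and "the series" means these few. Any claim that something is new, unique, unknown or untested is made for them only; others in the source may bear on it.

Three measured compounds share one core and differ only in the aryl group on the sulfonyl sulfur. Compound 1 `COc1ccc(-c2cc(=O)c3c(OC)cc(OC)cc3n2S(=O)(=O)c2ccc([N+](=O)[O-])cc2)cc1` carries a 4-nitrophenyl there; in a functional assay on HepG2 cells (Homo sapiens) for antiproliferative activity, with a stated time of 72 h (a higher number here means that more compound is needed for the effect, a lower number that less compound is needed), compound 1 gives only a limit, > 29300 nM. Compound 2 `COc1ccc(-c2cc(=O)c3c(OC)cc(OC)cc3n2S(=O)(=O)c2ccc(C#N)cc2)cc1` carries a 4-cyanophenyl, and in this assay compound 2 likewise gives a limit, > 17200 nM. Compound 3 `COc1ccc(-c2cc(=O)c3c(OC)cc(OC)cc3n2S(=O)(=O)c2cc(F)c(F)c(F)c2)cc1` carries a 3,4,5-trifluorophenyl; in this assay compound 3 also stands at a limit, > 65500 nM. The steps a step that the two limits leave unreadable from compound 1 to compound 2, a step that the two limits leave unreadable from compound 1 to compound 3 and a step that the two limits leave unreadable from compound 2 to compound 3 cannot be read, since (the limit of > 17200 nM in this assay, at which 1 of the 3 values shown sits), the limit of > 29300 nM in this assay, at which 1 of the 3 values shown sits, and the limit of > 65500 nM in this assay, at which 1 of the 3 values shown sits, each mark a limit and not a number.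

Compound 4 `COc1ccc(-c2cc(=O)c3c(OC)cc(OC)cc3n2S(=O)(=O)c2cc(Cl)cc(Cl)c2O)cc1` is not yet measured. Its change from compound 3 is 3,5-dichloro-2-hydroxyphenyl in place of 3,4,5-trifluorophenyl on a sulfonyl sulfur. All three measured steps bear on the same position, but none of them gives a readable size or direction, so nothing measured points to a step beyond the scatter in this assay. Compound 4 is therefore expected in this assay at about 30000 nM, within 5000 nM to 100000 nM. The step of an at least 2.1-fold lower number from compound 3 to compound 4 (0.33 log units; beyond the scatter) is an estimate only.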

Compound 4, half-maximal effective concentration: > 37900 nM
Compound 4: only a limit was reported; the forecaster's own chance of this, stated with the estimate: 65%; middle value at least 1.2-fold (0.10 log units) from the limit.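

In this assay compound 4 also gives only a limit, > 37900 nM. With all four values limits, the steps from compound 1, compound 2 and compound 3 to compound 4 cannot be read. The compounds shown leave open whether these four sulfonyl aryl groups differ at all in this assay.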